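Removing a Protecting Group and Cell Toxicity in Macrophages

The source may report more compounds than this note shows. Statements on the series, on what has been measured and on what is new or still open speak of the compounds shown alone.

Four related compounds are compared here for how much they harm cells in an ADME assay on RAW264.7 cells (Mus musculus) for cytotoxicity, read by resazurin assay, with a stated time of 48 h; on this read-out higher numbers stand for lower toxicity in this test and lower numbers for higher toxicity in this test. Compound 1 `CC(C)(C)OC(=O)NCCCCNCCCN(Cc1ccc(OCc2ccccc2)cc1)Cc1ccc(OCc2ccccc2)cc1` carries a tert-butoxycarbonyl group on a terminal amine nitrogen; in this assay compound 1 gives 33300 nM. Compound 2 `NCCCCNCCCN(Cc1ccc(OCc2ccccc2)cc1)Cc1ccc(OCc2ccccc2)cc1` is the same molecule with that group taken off, a change described as hydrogen in place of tert-butoxycarbonyl on an amine nitrogen. For compound 2 this assay reports only a limit, > 100000 nM, rather than a number. The step is therefore an at least 3.0-fold higher number from compound 1 to compound 2 (0.47 log units; beyond the scatter), which points toward lower toxicity once the protecting group is gone; this rests on (the limit of > 100000 nM in this assay, at which 1 of the 3 values shown sits).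

Compound 3 `CC(C)(C)OC(=O)NCCCCN(CCCN(Cc1ccc(F)cc1)Cc1ccc(F)cc1)CCCN(Cc1ccc(F)cc1)Cc1ccc(F)cc1` has a different, larger core, and the difference between the cores of compound 1 and compound 3 is not broken down here. In this assay compound 3 gives 12000 nM, the lowest number among the measured compounds. Compound 4 `NCCCCN(CCCN(Cc1ccc(F)cc1)Cc1ccc(F)cc1)CCCN(Cc1ccc(F)cc1)Cc1ccc(F)cc1` has not yet been measured; it differs from compound 3 by hydrogen in place of tert-butoxycarbonyl on an amine nitrogen, the same change seen between compound 1 and compound 2, at a place with the same surroundings.

From that earlier step, compound 4 is expected to show a step of a 3.3-fold higher number from compound 3 to compound 4 (0.52 log units; beyond the scatter) toward lower toxicity. The estimated value for compound 4 in this assay is 40000 nM, expected to lie between 15000 nM and 120000 nM.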

Compound 4, half-maximal cytotoxic concentration: 1500 nM
Compound 4: the middle estimate sits 27-fold (1.43 log units) above what was measured; the measured number lies below the stated range.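

Removing the tert-butoxycarbonyl group from the amine nitrogen does not have the same result on the two cores: in this assay the change now gives an 8.0-fold lower number from compound 3 to compound 4 (0.90 log units; beyond the scatter), meaning higher toxicity in this test, whereas the earlier step pointed toward lower toxicity. The two steps run in opposite directions, and the gap between them is larger than repeated measurements would be expected to produce: the same change on two cores in this assay, an at least 3.0-fold higher number (0.47 log units; beyond the scatter) from compound 1 to compound 2 and an 8.0-fold lower number (0.90 log units; beyond the scatter) from compound 3 to compound 4, at least 24-fold (1.38 log units) apart, beyond the scatter of two such steps Compound 2 is reported only as a limit and not as a number, which leaves the full size of the earlier step unknown, and these two pairs show neither why the steps differ nor which part of the core matters, only that the result from one core could not be carried over to the other: the limit of > 100000 nM in this assay, at which 1 of the 4 values shown sits.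

The compounds shown leave open which of the differences between the two cores goes with the change in direction, as no pair here alters just one part of the core. Also open, from the compounds shown here alone, is what happens with an acetyl group or a methyl group on that terminal amine nitrogen, and whether a shorter chain leading to the amine would give a similar result.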